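The source may report more compounds than this note shows. Statements on the series, on what has been measured and on what is new or still open speak of the compounds shown alone.

Working notes on the series in a physicochemical assay for lipophilicity, read by HPLC, in phosphate buffer, measured as octanol-water partition, with a stated time of 1 h, at pH 7.4; a lower number here means a more polar compound, a higher number a more lipophilic compound. Of the compounds shown here, three have been measured. Compound 1 `COc1cnc(C(=O)Nc2ccc(F)c([C@]3(C)C=C(CF)OC(N)=N3)c2)cn1` gives 2.7. Compound 3 `COc1cc(C#N)cnc1C(=O)Nc1ccc(F)c([C@]2(C)C=C(CF)OC(N)=N2)c1` gives 1.9; the step of a number 0.80 log units lower from compound 1 to compound 3 (beyond the scatter) covers 5-cyano-3-methoxypyridin-2-yl in place of 5-methoxypyrazin-2-yl on a carbonyl carbon. Compound 2 `CC1=C[C@@](C)(c2cc(NC(=O)c3ccc(C#N)cn3)ccc2F)N=C(N)O1` gives 2.2, the second highest of the three numbers: it sits within the scatter of compound 3, while compound 1 stands higher than compound 2 by a margin beyond the scatter.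

The next compound in line is compound 4 `C[C@@]1(c2cc(NC(=O)c3ccc(C#N)cn3)ccc2F)C=COC(N)=N1`. Relative to compound 2 the change is hydrogen in place of methyl on a double-bonded ring carbon; the carbon that is removed sits next to the ring oxygen, two ring bonds from the ring atom that bears the amino group. Among the compounds with values here, no measured step bears directly on this change: the one step recorded so far swaps the aryl group on the carbonyl carbon and is of a different kind, so its size is no guide here.

Within the data shown here, with no directly comparable step in this assay, the expectation rests on the loss of one heavy atom, a carbon, with nothing entering in its place; a modest lowering is expected, as the step of a number 0.40 log units lower from compound 2 to compound 4 (beyond the scatter). For compound 4 the estimate in this assay is 1.8, expected to fall between 1.4 and 2.2.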

Compound 4, distribution coefficient: 2
Beside the measured number, compound 4's estimate is 0.20 log units below it; the measured number falls inside the stated range.
By their numbers in this assay, from the lowest: compounds 3, 4 and 2 (each within the scatter of the next); then compound 1.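

In this assay, within the data shown here, hydrogen in place of methyl on a double-bonded ring carbon, next to the ring oxygen, gives a number 0.20 log units lower from compound 2 to compound 4 (within the scatter), a first reading at this position of the shared core and one that does not separate compound 2 from compound 4. Among these compounds, the only step recorded before this one, a number 0.80 log units lower from compound 1 to compound 3 (beyond the scatter), lies on the aryl group at the carbonyl carbon, whereas this pair shows that, with the 5-cyanopyridin-2-yl amide held constant, exchanging methyl for hydrogen at this ring carbon leaves the two numbers within the scatter of each other, a statement that covers this single pair and no other amide. No supporting evidence bears on this result, and it gives no explanation for the outcome.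

The fluoromethyl group of compound 1 and compound 3 sits on the same ring carbon but has no partner carrying hydrogen or methyl there with the same amide, which leaves its step unreadable. Also open, going by these compounds, is whether a longer chain such as ethyl, or an amine on this carbon, would give a step beyond the scatter.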